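Swapping the ester acyl group on the least toxic analogue

The source may report more compounds than this note shows. Statements on the series, on what has been measured and on what is new or still open speak of the compounds shown alone.

Of the compounds shown here, three of one series have been tested in an ADME assay on HepG2 2.2.15 cells (Homo sapiens) for cytotoxicity; on this read-out lower numbers stand for higher toxicity in this test and higher numbers for lower toxicity in this test. For the measured compounds named here, compound 1 `C=CCn1c(=O)c(CCO)c(-c2ccccc2Cl)c2cc(Cl)ccc21` gives 23000 nM, and compound 2 `O=c1c(CCO)c(-c2ccccc2Cl)c2cc(Cl)ccc2n1-c1ccccc1` gives 26000 nM; the only one-point step among them, a 1.1-fold higher number from compound 1 to compound 2 (0.05 log units; within the scatter), concerns the substituent on the aromatic nitrogen and stays within the scatter. Compound 3 `CC(=O)OCC(=O)OCCc1c(-c2ccccc2Cl)c2cc(Cl)ccc2[nH]c1=O` gives 100000 nM, the highest of the three numbers: it lies beyond the scatter above both compound 2 and compound 1, so it is the least toxic of the measured set in this assay.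

Compound 4 `O=C(OCCc1c(-c2ccccc2Cl)c2cc(Cl)ccc2[nH]c1=O)c1cccs1` differs from compound 3 only at the carbonyl carbon of the side chain: thiophen-2-yl in place of acetoxymethyl on a carbonyl carbon. Going by the values given here, no measured pair in this set alters that part of the molecule, so nothing bears directly on the change; the single step on record, between compound 1 and compound 2, touches another site and was within the scatter. Because compound 3 already gives 100000 nM and the one known substitution moved the read-out little, compound 4 is expected to stay close to it, with a step of a 1.7-fold lower number from compound 3 to compound 4 (0.22 log units; within the scatter) that is not expected to exceed the scatter. The estimate for compound 4 in this assay is 60000 nM, within a range of 20000 nM to 150000 nM.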

Compound 4, half-maximal cytotoxic concentration: > 1700000 nM
Compound 4: no number, only a limit (the forecaster's own chance of this, stated with the estimate: 30%); middle value at least 28-fold (1.45 log units) from the limit.
By their numbers in this assay, from the lowest: compounds 1 and 2 (each within the scatter of the next); then compound 3. At a limit, above all of these: compound 4.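

In this assay, for the compounds shown here, the group on the carbonyl carbon of the side-chain ester proves to be a site of real consequence: thiophen-2-yl in place of acetoxymethyl gives an at least 17-fold higher number from compound 3 to compound 4 (1.23 log units; beyond the scatter), whereas the only earlier step, a 1.1-fold higher number from compound 1 to compound 2 (0.05 log units; within the scatter), concerned the substituent on the aromatic nitrogen. On these data alone, for compound 4 the result is a limit of the assay and not a number: the limit of > 1700000 nM in this assay, at which 1 of the 4 values shown sits. The true size of the step therefore remains unknown, and since both groups hold 5 heavy atoms, the change lies in what those atoms are and how they are arranged, with one five-membered aromatic ring entering and an open acetoxymethyl leaving.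

As far as these compounds go, this single pair cannot separate the aromatic ring as such from its sulfur, and whether a phenyl, a furan-2-yl or a plain methyl on the same carbonyl carbon would follow compound 4 or compound 3 remains open. Also open, from the compounds shown here alone, is whether thiophen-2-yl on this carbonyl carbon would have the same effect with allyl or phenyl on the aromatic nitrogen.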